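This account rests on a few compounds, and the source may have more. Where it says the series, first, only, none or still open, it means among the compounds named here.

Measured compounds, with their values in a functional assay on MCF7 cells (Homo sapiens) for inhibition, with a stated time of 96 h; on this read-out higher numbers stand for weaker inhibition and lower numbers for stronger inhibition:

compound 1, `COc1cc(C(=O)c2cn(-c3cccc(C)c3)cc2-c2ncco2)cc(OC)c1OC`, gives 75 nM
compound 2, `COc1cc(C(=O)c2cn(-c3ccc(C)cc3)cc2-c2ncco2)cc(OC)c1OC`, gives 42 nM
compound 3, `COc1cc(C(=O)c2cn(-c3cccc(C)c3)cc2-c2ccccn2)cc(OC)c1OC`, gives 140 nM

Compound 1 and compound 2 share a core and differ only in the group on the aromatic nitrogen: 4-methylphenyl in place of 3-methylphenyl on an aromatic nitrogen. This change gave a 1.8-fold lower number from compound 1 to compound 2 (0.25 log units; within the scatter). Compound 1 and compound 3 differ in the group on the aromatic carbon: pyridin-2-yl in place of 1,3-oxazol-2-yl on an aromatic carbon. That change gave a 1.9-fold higher number from compound 1 to compound 3 (0.27 log units; within the scatter). Within the data shown here, of compound 2 and compound 3 no direct step is known; their two values differ beyond the scatter, with compound 3 carrying the higher number.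

Compound 4, `COc1cc(C(=O)c2cn(-c3ccc(C)cc3)cc2-c2ccccn2)cc(OC)c1OC`, is not yet measured in this assay. It relates to compound 3 as compound 2 relates to compound 1: 4-methylphenyl in place of 3-methylphenyl on an aromatic nitrogen. The surroundings are not identical, though: in compound 1 the ring atom two ring bonds from the place bears a 1,3-oxazol-2-yl group, in compound 3 it bears a pyridin-2-yl group, so this is the same kind of change rather than the same change. How the cores of compound 1 and compound 3 differ is told by the step from compound 1 to compound 3 above.

Among the measured compounds shown here, for compound 4 a step of about the size a 1.8-fold lower number from compound 1 to compound 2 (0.25 log units; within the scatter) is expected, since that is the one example of this kind of change; the estimated step is a 1.8-fold lower number from compound 3 to compound 4 (0.24 log units; within the scatter), resting on compound 3 at 140 nM. Compound 4 is thus estimated at 80 nM, with a likely range from 40 nM to 160 nM.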

Compound 4, half-maximal inhibitory concentration: 36 nM
Beside the measured number, compound 4's estimate is 2.2-fold (0.35 log units) above it, and the stated range ends above it.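

In this assay, 4-methylphenyl in place of 3-methylphenyl on the aromatic nitrogen gives a 3.9-fold lower number from compound 3 to compound 4 (0.59 log units; beyond the scatter), and this step agrees with the earlier one on the other core: the same change on two cores in this assay, a 1.8-fold lower number (0.25 log units; within the scatter) from compound 1 to compound 2 and a 3.9-fold lower number (0.59 log units; beyond the scatter) from compound 3 to compound 4, 2.2-fold (0.34 log units) apart, within the scatter of two such steps. The swap on the aromatic carbon, pyridin-2-yl in place of 1,3-oxazol-2-yl, gives a 1.2-fold lower number from compound 2 to compound 4 (0.07 log units; within the scatter) and likewise agrees with its earlier counterpart: the same change on two cores in this assay, a 1.9-fold higher number (0.27 log units; within the scatter) from compound 1 to compound 3 and a 1.2-fold lower number (0.07 log units; within the scatter) from compound 2 to compound 4, 2.2-fold (0.34 log units) apart, within the scatter of two such steps. Among these compounds, both methylphenyl steps therefore run towards a lower number and can be read as one step within the scatter, although only the step on the pyridin-2-yl core is itself beyond the scatter; two cores do not show that the change carries to any further core, nor do they rule out a modest dependence on the core.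

Still open, as far as these compounds go, is what happens when the methyl group on the phenyl ring gives way to a methoxy group, a chlorine atom, an amine or a longer alkyl chain. Equally open, from the compounds shown here alone, is how other groups on the aromatic carbon, such as a carboxylic acid or a simple phenyl ring, would behave alongside either methylphenyl group.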